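This account rests on a few compounds, and the source may have more. Where it says the series, first, only, none or still open, it means among the compounds named here.

Working notes on the series built on the shared core of compound 1 `Cc1cc(Nc2ccc(Cl)cc2)nc(SCc2nc3ccccc3[nH]2)n1`, with compound 2 `Cc1cc(NCCO)nc(SCc2nc3ccccc3[nH]2)n1` and compound 3 `Cc1ccc(Nc2cc(C)nc(SCc3nc4ccccc4[nH]3)n2)cc1` beside it. In a functional assay on MGC-803 cells (Homo sapiens) for cytotoxicity, read by MTT assay, with a stated time of 72 h (a lower number here means a stronger inhibitor, a higher number a weaker inhibitor), compound 1 gives 28200 nM. Compound 3 gives 7390 nM in this assay. For compound 2 this assay reports only a limit, > 100000 nM, so compound 2 stands at the weak end of the numbers shown, at the limit of > 100000 nM in this assay, at which 1 of the 3 values shown sits, rather than at a measured value.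

Compound 4 `Cc1cc(N(C)Cc2ccccc2)nc(SCc2nc3ccccc3[nH]2)n1` is the next member to be measured. It differs from compound 2 by benzyl(methyl)amino in place of (2-hydroxyethyl)amino on an aromatic carbon. Within the data shown here, two measured steps bear on this change, both exchanging the 2-hydroxyethyl on that nitrogen for an aryl group: an at least 3.5-fold higher number from compound 1 to compound 2 (0.54 log units; beyond the scatter) and an at least 13-fold lower number from compound 2 to compound 3 (1.13 log units; beyond the scatter). Both run in the same direction, away from the limit at which compound 2 sits. Benzyl(methyl)amino brings in a six-membered aromatic ring of carbon only, as the 4-chlorophenyl and 4-methylphenyl groups do, but with one more carbon between nitrogen and ring and without a hydrogen-bond donor, so the step is expected to run the same way, at about the size of an at least 5.0-fold lower number from compound 2 to compound 4 (0.69 log units; beyond the scatter), though the limit value of compound 2 leaves its true size uncertain. For compound 4 the estimate in this assay is 20000 nM, within a range from 5000 nM to 100000 nM.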

Compound 4, half-maximal inhibitory concentration: 31300 nM
Compound 4: middle estimate off by 1.6-fold (0.19 log units), on the low side, and the stated range covers the measured number.
By their numbers in this assay, from the lowest: compound 3; then compounds 1 and 4 (each within the scatter of the next). At a limit, above all of these: compound 2.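

In this assay, among these compounds, (4-chlorophenyl)amino and (4-methylphenyl)amino are no longer the only groups at this position with a measured number, since benzyl(methyl)amino also comes away from the limit, with an at least 3.1-fold lower number from compound 2 to compound 4 (0.50 log units; beyond the scatter). A hydrogen-bond donor on this nitrogen is not required for activity at the level of compound 1: benzyl(methyl)amino has none, yet the change gives a 1.1-fold higher number from compound 1 to compound 4 (0.05 log units; within the scatter), so the two groups cannot be told apart here. An aromatic ring of carbon only does not by itself set the number, however, as the change from (4-methylphenyl)amino gives a 4.2-fold higher number from compound 3 to compound 4 (0.63 log units; beyond the scatter), and compound 3 keeps the lowest number of the four.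

From the compounds shown here alone, the true size of the step from the hydroxyethyl compound stays open because compound 2 sits at a limit: the limit of > 100000 nM in this assay, at which 1 of the 4 values shown sits. Going by these compounds, the benzyl ring and the methyl on the nitrogen enter together in compound 4, so their separate contributions remain open, and a plain benzylamino group or a morpholine ring at this position would bear on that question.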